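Adding a Third Methoxy to a Triazole Thioether Scaffold

The source may report more compounds than this note shows. Statements on the series, on what has been measured and on what is new or still open speak of the compounds shown alone.

Among the compounds with values here, compound 1, `COc1ccc(-c2nnc(SCC(=O)c3ccccc3)n2-c2ccccc2)cc1OC`, is one of two compounds measured in a functional assay on the whole organism (strain albino) for inhibition, with Rattus norvegicus as the target, read by paw edema, with a stated time of 4 h, at a dose of 0.28 mmol/kg by the oral route; on this read-out higher numbers stand for more inhibition at the one dose given (going by the name of the read-out) and lower numbers for less inhibition. In this assay compound 1 gives 65%, the lower of the two numbers. Its companion, compound 2, `COc1ccc(-c2nnc(SC/C(=N/O)c3ccccc3)n2-c2ccccc2)cc1OC`, differs from it only on the saturated chain carbon bound to a sulfur, and compound 2 gives 81% in this assay; the single step shown is a number 16 percentage points higher from compound 1 to compound 2 (beyond the scatter).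

The unmeasured compound 3, `COc1cc(-c2nnc(SCC(=O)c3ccccc3)n2-c2ccccc2)cc(OC)c1OC`, leaves that chain untouched and instead alters the aromatic ring carrying two methoxy groups: methoxy in place of hydrogen on an aromatic carbon. Within the data shown here, no measured step touches this ring, so the change from compound 1 to compound 2, which concerns the chain and not the ring, gives no guidance on how a third methoxy will read out. With nothing to push the expectation in either direction, the step is expected to stay within the scatter, no change at the digits printed from compound 1 to compound 3 (within the scatter). Compound 3 is therefore estimated to give 65% in this assay, within a range of 50% to 80%.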

Compound 3, a percentage reported as inhibition, in the whole organism at one dose (the size of the read-out at that dose, not a potency): 73%
Compound 3: middle estimate off by 8 percentage points, on the low side; low and high end bracket the measured number.
By their numbers in this assay, from the lowest: compounds 1, 3 and 2 (each within the scatter of the next, the first and the last beyond it).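

In this assay, methoxy in place of hydrogen on an aromatic carbon, ortho to a methoxy group and meta to a large group, gives a number 8 percentage points higher from compound 1 to compound 3 (within the scatter), so this step cannot be told apart from the ordinary spread of repeated measurements. Within the data shown here, this is the first look at the ring carrying the methoxy groups, since the earlier step concerned only the chain on the sulfur, and it shows that this position can carry a third methoxy while the read-out stays within that spread; a real small gain and no change at all remain equally possible. Nothing available on the compounds explains the result or links it to any property of the methoxy group.

The compounds shown leave open whether a different group at this same position, such as a hydroxyl, a chlorine, an amine or a longer ethoxy chain, would move the number beyond the scatter. They also leave open how the third methoxy would read out when combined with the chain of compound 2, which carries a different group on that chain.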